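The compounds below may be only part of what the source reports. "The series", "measured", "known", "first", "only" and "open" are said of these compounds alone.

Working notes on the series. The shared core is that of compound 1 `COC(=O)c1cc2c(N)cccc2n(Cc2ccc(OC)cc2)c1=O`; compound 2 `COC(=O)c1cc2c(NC(=O)CCC3CCCCC3)cccc2n(Cc2ccc(OC)cc2)c1=O` and compound 3 `COC(=O)c1cc2c(NC(=O)CC3CCCCC3)cccc2n(Cc2ccc(OC)cc2)c1=O` carry amides on the ring amine. Among the compounds with values here, in an assay on HEK293 cells for antagonist activity at P2X purinoceptor 7 (Homo sapiens), read by fluorescence, with a stated time of 2 h (on this read-out lower numbers stand for stronger inhibition and higher numbers for weaker inhibition), compound 1 gives "not determined" (no result reported), compound 2 gives "not determined" (no result reported), and compound 3 gives 875 nM, so compound 3 stands as the only entry with a number in this assay and nothing can be said of its rank. Within the data shown here, no step between measured compounds is available. Compound 4 `COC(=O)c1cc2c(NC(=O)C3CCCCC3)cccc2n(Cc2ccc(OC)cc2)c1=O` differs from compound 3 by cyclohexyl in place of cyclohexylmethyl on a carbonyl carbon. Without a measured step to lean on, the expected change in this assay from compound 3 to compound 4 is a 1.1-fold higher number from compound 3 to compound 4 (0.06 log units; within the scatter), not beyond the usual scatter. Compound 4 is therefore estimated at 1000 nM, with a range from 300 nM to 3500 nM.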

Compound 4, half-maximal inhibitory concentration: 810 nM
Compound 4: middle estimate off by 1.2-fold (0.09 log units), on the high side; measured number inside the range.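

In this assay, within the data shown here, cyclohexyl in place of cyclohexylmethyl on a carbonyl carbon gives a 1.1-fold lower number from compound 3 to compound 4 (0.03 log units; within the scatter) as the first measured step at this position. On this read-out, compound 3 and compound 4 stand level, so this position accepts both groups with no difference that can be read. No available evidence bears on this result. What the compounds shown leave open is how a phenyl ring, an amine or a carboxylic acid on this carbonyl carbon would read in this assay. They also leave open whether the ester and the methoxybenzyl group of the shared core can be replaced.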